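The source may report more compounds than this note shows. Statements on the series, on what has been measured and on what is new or still open speak of the compounds shown alone.

Values so far in a functional assay on K562 cells (Homo sapiens) for inhibition, read by luminescence, with a stated time of 72 h, tested at 5 uM; a higher number here means more inhibition of growth at the concentration tested, a lower number less inhibition of growth
compound 1 `C=CS(=O)(=O)NC/C=C/c1cc(OC)cc(O)c1C(=O)OCC1CCCCC1` gives 27.4%
compound 2 `COc1cc(O)c(C(=O)OCC(C)c2ccccc2)c(/C=C/CN2C(=O)C=CC2=O)c1` gives 74.9%
compound 3 `COc1cc(O)c(C(=O)OC(C)C)c(/C=C/CN2C(=O)C=CC2=O)c1` gives 95.7%

Compound 3 stands highest of the three, and its gaps to compound 2 and compound 1 both lie beyond the scatter. The next compound is compound 4 `COc1cc(O)c(C(=O)OCC2CCCCC2)c(/C=C/CN2C(=O)C=CC2=O)c1`, and the change from compound 3 is cyclohexylmethyl in place of isopropyl on an oxygen next to a carbonyl group. Going by the values given here, one measured step bears directly on this place: a number 20.8 percentage points higher from compound 2 to compound 3 (beyond the scatter), with isopropyl in place of 2-phenylpropyl. Compound 1 also carries cyclohexylmethyl and gives 27.4%, but it differs elsewhere too, so it does not isolate this change. Cyclohexylmethyl, like 2-phenylpropyl, is larger than isopropyl. In this assay the expected step is therefore downward and of similar modest size, a number 18.7 percentage points lower from compound 3 to compound 4 (beyond the scatter) (an estimate resting on that single pair). For compound 4 the estimated value is 77% (expected range 55% to 94%).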

Compound 4, percent growth inhibition at one concentration: 85.1%
For compound 4 the middle estimate is 8.1 percentage points below the measured one, within the range that was stated.
By their numbers in this assay, from the lowest: compound 1; then compound 2; then compound 4; then compound 3.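

In this assay, cyclohexylmethyl on an oxygen next to a carbonyl group also ranks under isopropyl, a number 10.6 percentage points lower from compound 3 to compound 4 (beyond the scatter), so the downward step seen with 2-phenylpropyl is not confined to that one group. The two larger groups also differ from each other, a number 10.2 percentage points higher from compound 2 to compound 4 (beyond the scatter), so the ranking at this place does not follow from leaving isopropyl alone and depends on which group enters. With cyclohexylmethyl held constant, the five-membered non-aromatic ring group in place of the sulfur-bearing chain group gives the largest step in the series, a number 57.7 percentage points higher from compound 1 to compound 4 (beyond the scatter), which exceeds every step at the ester oxygen.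

Going by these compounds, how a methyl group or a chain ending in an amine would read at this oxygen remains open. Nothing available explains the size or direction of these steps.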